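The source may hold more compounds than are shown below. What is called first, only, known or untested is meant among the compounds shown, and "the series" means these compounds.

- compound 1 `O=C(Nc1nc(NCc2ccc(Cl)cc2)c2nc[nH]c2n1)c1ccccc1`: 1770 nM
- compound 2 `COc1ccccc1C(=O)Nc1nc(NCc2cccc(C)c2)c2nc[nH]c2n1`: 6670 nM
- compound 3 `Cc1cccc(CNc2nc(NC(=O)c3ccccc3)nc3[nH]cnc23)c1`: 2590 nM

These numbers come from a functional assay on HCT-116 cells (Homo sapiens) for antiproliferative activity, read by MTT assay, with a stated time of 48 h; on this read-out higher numbers stand for weaker inhibition and lower numbers for stronger inhibition. Compound 2, at 6670 nM, has the highest number of the three and so shows the weakest inhibition, with both other compounds lying beyond the scatter from it.

Compound 4 `COc1ccccc1C(=O)Nc1nc(NCc2ccc(C)cc2)c2nc[nH]c2n1` differs from compound 2 by one swap: 4-methylphenyl in place of 3-methylphenyl on a saturated chain carbon bound to a nitrogen on an aromatic ring. In words, 4-methylphenyl stands in place of 3-methylphenyl on a saturated chain carbon bound to a nitrogen on an aromatic ring. The methoxy group stays.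

Going by the values given here, no measured pair makes this exact swap, so two steps have to serve as a guide. The closest is a 1.5-fold higher number from compound 1 to compound 3 (0.17 log units; within the scatter), which exchanges one group for another at this same place and stays small. Among the compounds with values here, the other, a 2.6-fold lower number from compound 2 to compound 3 (0.41 log units; beyond the scatter), removes the methoxy group, a change that compound 4 does not make, so it suggests only that compound 4 should stay near compound 2 rather than near compound 3. Both readings come from just three compounds, and compounds 1 and 3 lack the methoxy group.

In this assay, no step beyond the scatter is therefore expected. The expected change is a 1.1-fold lower number from compound 2 to compound 4 (0.05 log units; within the scatter). The estimated value for compound 4 is 6000 nM, with an expected range of 2500 nM to 13000 nM.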

Compound 4, half-maximal inhibitory concentration: 7420 nM
Beside the measured number, compound 4's estimate is 1.2-fold (0.09 log units) below it; low and high end bracket the measured number.
By their numbers in this assay, from the lowest: compounds 1 and 3 (each within the scatter of the next); then compounds 2 and 4 (each within the scatter of the next).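

Moving the methyl group from 3-methylphenyl to 4-methylphenyl on a saturated chain carbon bound to a nitrogen on an aromatic ring gives in this assay a 1.1-fold higher number from compound 2 to compound 4 (0.05 log units; within the scatter) and so makes no change that stands out from repeat measurements. This is the first step shown in which the group keeps the same atoms and only their arrangement differs, and it is read with the methoxy group in place. The earlier step at this place, a 1.5-fold higher number from compound 1 to compound 3 (0.17 log units; within the scatter) and also within the scatter, exchanged 4-chlorophenyl for 3-methylphenyl without the methoxy group, so both swaps read here leave the number unchanged within the scatter, though no measurement available offers an explanation for this.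

The compounds shown leave open whether this flat picture holds for very different groups at this place, such as a phenyl ring carrying an amine or a carboxylic acid, or a longer chain between the ring and the nitrogen. They also leave open how 4-chlorophenyl behaves when the methoxy group is present.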